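From Fluoro to Nitro on a Dithiol Anilide

A few compounds are considered here, and "the series" means these few. Any claim that something is new, unique, unknown or untested is made for them only; others in the source may bear on it.

compound 1 `O=C(CCCCC(S)CCS)Nc1ccc(F)cc1` gives 5.64%
compound 2 `O=C(CCCCC(S)CCS)Nc1cccc(C(F)(F)F)c1` gives 12%

Both compounds were tested in a functional assay on NCI-H460 cells (Homo sapiens) for inhibition, read by MTT assay, with a stated time of 24 h, tested at 0.1 ug/mL (a lower number here means less inhibition of growth, a higher number more inhibition of growth at the concentration tested), and share the same thiol-bearing chain. Compound 1 gives 5.64% and stands within the usual scatter of compound 2 at 12% in this comparison, so neither can be ranked above the other. Within the data shown here, these two compounds differ in more than one place, which leaves no measured single-place step to serve as a guide.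

The next compound, compound 3 `O=C(CCCCC(S)CCS)Nc1ccc([N+](=O)[O-])cc1`, has not yet been measured. It carries nitro in place of fluoro on an aromatic carbon, para to a large group, and the rest of compound 1 stays unchanged nitro in place of fluoro on an aromatic carbon in this step. With compound 1 at 5.64% and compound 2 at 12% as the only reference points, no change beyond the scatter is expected, though a slight rise would not surprise. The expected step of a number 4.4 percentage points higher from compound 1 to compound 3 (within the scatter) lies within the scatter of this assay as estimated here. For compound 3 the estimate is 10% with an expected range of 2% to 22% at this single concentration.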

Compound 3, percent growth inhibition at one concentration: 5.69%
Beside the measured number, compound 3's estimate is 4.3 percentage points above it; low and high end bracket the measured number.
By their numbers in this assay, from the lowest: compounds 1, 3 and 2 (each within the scatter of the next).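

Among these compounds, compound 3 provides the first step that changes a single place: nitro in place of fluoro on an aromatic carbon, para to a large group, gives a number 0.1 percentage points higher from compound 1 to compound 3 (within the scatter) in this assay and so leaves the two compounds indistinguishable at this one concentration. At this position, a nitro group with 3 heavy atoms and 2 hydrogen-bond acceptors stands where a single fluorine stood, yet the read-out does not separate the two, something the earlier pair, which differed in more than one place, could not show. No measurement shown here accounts for this outcome or tells what this position contributes in the cells.

From the compounds shown here alone, it remains open whether any other group at this position would separate from fluoro in this assay for example an amine, a carboxylic acid or a methoxy group. Also open, going by these compounds, are whether compound 1 and compound 3 would remain indistinguishable at higher concentrations, and what a shorter chain, or a chain carrying hydroxyl groups in place of the thiols, would give.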